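The source may hold more compounds than are shown below. What is called first, only, known or untested is meant among the compounds shown, and "the series" means these compounds.

Compound 1 `CCOC(=O)c1cnc(C)nc1NN1C(=O)C=C(C)C1=O`: 16000 nM in a functional assay on Jurkat cells for inhibition of nuclear factor NF-kappa-B complex (Homo sapiens); on this read-out higher numbers stand for weaker inhibition and lower numbers for stronger inhibition
Compound 2 `CCOC(=O)c1cnc(CC)nc1NN1C(=O)C=C(C)C1=O`: 10000 nM
Compound 3 `CCOC(=O)c1cnc(-c2ccncc2)nc1NN1C(=O)C=C(C)C1=O`: 6000 nM

Among these three, compound 3 is separated from compound 1 by a 2.7-fold lower number from compound 1 to compound 3 (0.43 log units; beyond the scatter), a modest step beyond the scatter, while its value and that of compound 2 lie within the scatter of each other. Compound 4 `CCOC(=O)c1cnc(-c2csc(C)n2)nc1NN1C(=O)C=C(C)C1=O` differs from compound 3 by 2-methyl-1,3-thiazol-4-yl in place of pyridin-4-yl on an aromatic carbon. Among the compounds with values here, no measured step exchanges one aromatic group for another; the only steps that touch this position are a 2.7-fold lower number from compound 1 to compound 3 (0.43 log units; beyond the scatter) and a 1.7-fold lower number from compound 2 to compound 3 (0.22 log units; within the scatter), both replacements of a small alkyl group by pyridin-4-yl and both modest at most. With nothing to show that one aromatic group outperforms the other, no step beyond the scatter is expected in this assay, so compound 4 is estimated at 6000 nM, with a range from 2500 nM to 14000 nM, which means no change at the digits printed from compound 3 to compound 4 (within the scatter).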

Compound 4, half-maximal inhibitory concentration: 8000 nM
Estimate against measurement, compound 4: 1.3-fold (0.12 log units) below, and the stated range covers the measured number.
By their numbers in this assay, from the lowest: compounds 3, 4, 2 and 1 (each within the scatter of the next, the first and the last beyond it).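

In this assay, within the data shown here, the first exchange of one aromatic group for another on the carbon between two ring nitrogen atoms leaves 2-methyl-1,3-thiazol-4-yl and pyridin-4-yl within the scatter of each other (a 1.3-fold higher number from compound 3 to compound 4 (0.12 log units; within the scatter)). Unlike pyridin-4-yl, which stands beyond the scatter from methyl (a 2.7-fold lower number from compound 1 to compound 3 (0.43 log units; beyond the scatter)), 2-methyl-1,3-thiazol-4-yl stays within it of both ethyl (a 1.3-fold lower number from compound 2 to compound 4 (0.10 log units; within the scatter)) and methyl (a 2.0-fold lower number from compound 1 to compound 4 (0.30 log units; within the scatter)). Nothing measured here bears on the reason for this.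

The compounds shown leave open whether an unsubstituted phenyl ring, an amine or a carboxylic acid at this position would stand beyond the scatter from pyridin-4-yl.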